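Turning the double bond of compound 2 from E to Z

The source may report more compounds than this note shows. Statements on the series, on what has been measured and on what is new or still open speak of the compounds shown alone.

Measured in a functional assay on A549 cells (Homo sapiens) for inhibition; on this read-out higher numbers stand for weaker inhibition and lower numbers for stronger inhibition:
- compound 1 `C(=C\c1ccco1)\c1ccc2ccccc2c1`: > 5000 nM (a limit)
- compound 2 `C(=C/c1ccc2ccccc2c1)\c1ccoc1`: > 5000 nM (a limit)

Compound 2 gives > 5000 nM, which is a limit of the assay and not a number. Among the compounds with values here, it shares this position with compound 1, so the whole series so far stands at the limit of > 5000 nM in this assay, at which 2 of the 2 values shown sit. Neither compound has yet given a measured potency.

Compound 3 `C(=C\c1ccc2ccccc2c1)\c1ccoc1` is the next to be tested in this assay. Its structural change is the two compounds have the same atoms and bonds and differ only in configuration as drawn: 1 of 1 stereo elements differ; a double bond is drawn E in compound 2 and Z in compound 3. Within the data shown here, no measured pair shows what such a change does here, so the expectation rests only on the limit reached by compound 2. The estimated step that the limit leaves unreadable from compound 2 to compound 3 is expected to be no larger than the scatter, with no clear direction, and a further limit is the likeliest report. For compound 3 the expected value is 6000 nM, within an estimated range of 2000 nM to 10000 nM.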

Compound 3, half-maximal inhibitory concentration: > 5000 nM
Compound 3 was reported as a limit; the forecaster's own chance of this, stated with the estimate: 70%; the middle value does not contradict the limit.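

Within the data shown here, compound 3 is reported as a limit, > 5000 nM, so no step from compound 1 or compound 2 to compound 3 can be read: the limit of > 5000 nM in this assay, at which 3 of the 3 values shown sit.

On these data alone, whether the double-bond configuration, or furan-3-yl in place of furan-2-yl, alters the read-out in this assay stays open.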